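A few compounds are considered here, and "the series" means these few. Any claim that something is new, unique, unknown or untested is made for them only; others in the source may bear on it.

Numbers in an assay on HEK293 cells for displacement of a labelled ligand from Melanocortin receptor 4 (Homo sapiens) (a lower number here means a stronger inhibitor, a higher number a weaker inhibitor), for the measured members of the series:

- compound 1 `CC(C)C[C@H](N)c1cc(C(F)(F)F)ccc1N1CCN(C(=O)CCC(N)=O)CC1`: > 10000 nM, a limit of the assay rather than a number
- compound 2 `CC(C)C[C@H](N)c1cc(C(F)(F)F)ccc1N1CCN(C(=O)C(C)Cc2ccc(Cl)cc2)CC1`: 47 nM
- compound 3 `CC(C)C[C@H](N)c1cc(C(F)(F)F)ccc1N1CCN(C(=O)[C@H](C)Cc2ccc(Cl)cc2)CC1`: 31 nM

Compound 3 and compound 2 are within the scatter of each other, the gap being a 1.5-fold lower number from compound 2 to compound 3 (0.18 log units; within the scatter); the pair differ only in that one is drawn with a defined configuration and the other without (the fact that one of compounds 2 and 3 is drawn with a defined configuration and the other without, at the place where they differ). The value of compound 1 is a limit (the limit of > 10000 nM in this assay, at which 1 of the 3 values shown sits), so the steps of an at least 210-fold lower number from compound 1 to compound 2 (2.32 log units; beyond the scatter) and an at least 320-fold lower number from compound 1 to compound 3 (2.50 log units; beyond the scatter) are lower bounds on the effect of putting 1-(4-chlorobenzyl)ethyl in place of 2-carbamoylethyl on the carbonyl carbon.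

Compound 4 `Cc1ccc(OCC(=O)N2CCN(c3ccc(C(F)(F)F)cc3[C@@H](N)CC(C)C)CC2)cc1` carries a different group at that same position: (4-methylphenoxy)methyl in place of 1-(4-chlorobenzyl)ethyl on a carbonyl carbon. Going by the values given here, the steps that bear on this change are the large ones from compound 1, which show that the group on the carbonyl carbon governs the number in this assay. Compound 4 keeps an aromatic ring there, so a step of the size seen from compound 1 is not expected; a moderate increase in the number relative to compound 3 is estimated, a 4.8-fold higher number from compound 3 to compound 4 (0.68 log units; beyond the scatter). Compound 4 is therefore expected at about 150 nM, within 40 nM to 600 nM.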

Compound 4, inhibition constant: 4400 nM
The estimate for compound 4 lay 29-fold (1.47 log units) below the measured number; the measured number lies above the stated range.
By their numbers in this assay, from the lowest: compounds 3 and 2 (each within the scatter of the next); then compound 4. At a limit, above all of these: compound 1.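

In this assay, an aromatic ring on the carbonyl carbon is not enough to keep the low numbers: (4-methylphenoxy)methyl also carries one six-membered aromatic ring of carbon only, yet the change gives a 140-fold higher number from compound 3 to compound 4 (2.15 log units; beyond the scatter) and a 94-fold higher number from compound 2 to compound 4 (1.97 log units; beyond the scatter). The group on the carbonyl carbon therefore matters beyond the presence of that ring, at least across these compounds. Compound 1 sits at a limit of the assay, so an at least 2.2-fold lower number from compound 1 to compound 4 (0.35 log units; beyond the scatter) is only a lower bound: the limit of > 10000 nM in this assay, at which 1 of the 4 values shown sits.

The change alters several things at once, with oxygen and one hydrogen-bond acceptor entering while chlorine and the defined stereocentre leave, and the compounds shown do not separate these. On these data alone, it remains open whether (4-chlorophenoxy)methyl or 1-(4-methylbenzyl)ethyl on the carbonyl carbon would stay nearer compound 3 or nearer compound 4.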